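Demethylation on a Chalcone Ring: An Expected Small Step

This account rests on a few compounds, and the source may have more. Where it says the series, first, only, none or still open, it means among the compounds named here.

Compound 1 `COc1cccc(/C=C/C(=O)c2ccc(OC)c3c2OC(C)(C)C=C3)c1` gives > 10000 nM in a functional assay on HCT-116 cells (Homo sapiens) for antiproliferative activity, read by MTT assay, with a stated time of 24 h (on this read-out higher numbers stand for weaker inhibition and lower numbers for stronger inhibition), which is a limit of the assay rather than a number.
Compound 2 `COc1ccc(C(=O)/C=C/c2cc(OC)c(OC)c(OC)c2)c2c1C=CC(C)(C)O2` gives 7650 nM in this assay.
Compound 3 `COc1ccc(C(=O)/C=C/c2cccc(O)c2)c2c1C=CC(C)(C)O2` gives > 10000 nM in this assay, again a limit of the assay.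

Compound 3 differs from compound 1 by hydrogen in place of methyl on an oxygen on an aromatic ring. The step that the two limits leave unreadable from compound 1 to compound 3 cannot be read, because both values sit at the limit of > 10000 nM in this assay, at which 2 of the 3 values shown sit. Among the compounds with values here, compound 2 is the only compound of the three with a number; how its core differs from that of compound 1 is not broken down here.

Compound 4 `COc1cc(/C=C/C(=O)c2ccc(OC)c3c2OC(C)(C)C=C3)cc(OC)c1O` has not yet been measured in this assay. It differs from compound 2 by hydrogen in place of methyl on an oxygen on an aromatic ring, the same change as from compound 1 to compound 3. The earlier step gives no readable size, so the expectation rests on compound 2 alone and its value of 7650 nM. The step of a 1.2-fold higher number from compound 2 to compound 4 (0.07 log units; within the scatter) is expected to stay within the usual scatter. Compound 4 is therefore estimated at 9000 nM, between 4000 nM and 20000 nM, with a fair chance that only a limit is reported.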

Compound 4, half-maximal inhibitory concentration: > 10000 nM
Compound 4 ended at the assay's limit; the forecaster's own chance of this, stated with the estimate: 40%; middle value at least 1.1-fold (0.04 log units) from the limit.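

Carried to a second pair of compounds, the change from methoxy to hydroxy gives an at least 1.3-fold higher number from compound 2 to compound 4 (0.11 log units; that floor lies within the scatter) in this assay. Compound 4 gives > 10000 nM, which is a limit of the assay and not a number. This shows that the change did not bring a reading under that limit on either core, but it does not show the true size of the step here, and the step between compound 1 and compound 3 cannot be read, so the change cannot be compared in size between the two cores: the limit of > 10000 nM in this assay, at which 3 of the 4 values shown sit.

The compounds shown leave open how far compound 4 truly lies from compound 2, as only a floor is known for that step. They also leave open whether an amine or a carboxylic acid in place of the hydroxy group, or a longer chain in place of the methyl on that oxygen, would give a reading that can be compared with compound 2.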